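Bromo substitution on the sulfonyl phenyl of compound 2

A few compounds are considered here, and "the series" means these few. Any claim that something is new, unique, unknown or untested is made for them only; others in the source may bear on it.

Compound 1 `COc1ccc(Nc2nc3ccccc3nc2S(=O)(=O)c2ccccc2)cc1` in a functional assay on KB cells (Homo sapiens) for cytotoxicity, read by MTT assay, with a stated time of 72 h (a lower number here means a stronger inhibitor, a higher number a weaker inhibitor), gives "not determined" (no result reported). Among the measured compounds shown here, compound 2 `O=S(=O)(c1ccccc1)c1nc2ccccc2nc1Nc1ccc(Cl)cc1` is thus the only measured reference; in this assay compound 2 gives 41200 nM, the sole number, and it stands as a weak inhibitor. Compound 3 `O=S(=O)(c1ccc(Br)cc1)c1nc2ccccc2nc1Nc1ccc(Cl)cc1` differs from compound 2 by bromo in place of hydrogen on an aromatic carbon. For the measured compounds named here, no step between measured compounds is available, so nothing here shows how such a change moves the read-out; a shift no larger than the scatter is expected a 1.4-fold lower number from compound 2 to compound 3 (0.14 log units; within the scatter), leaning if anything toward stronger inhibition. Compound 3 is estimated in this assay at 30000 nM, within 10000 nM to 90000 nM.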

Compound 3, half-maximal inhibitory concentration: 11600 nM
Estimate against measurement, compound 3: 2.6-fold (0.41 log units) above, within the range that was stated.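

In this assay, among the compounds shown here, phenyl to 4-bromophenyl gives a 3.6-fold lower number from compound 2 to compound 3 (0.55 log units; beyond the scatter), the first readable step, and it shows that this place on the sulfonyl phenyl responds to substitution. The gain is modest and rests on a single pair, so it sets no trend. No evidence at hand bears on why the number falls.

As far as these compounds go, whether fluoro, an amine or a carboxylic acid at the same place would move the number in the same direction remains open. Also open, from the compounds shown here alone, is whether the gain from bromo holds when the chloro of compound 3 is replaced.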